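This account rests on a few compounds, and the source may have more. Where it says the series, first, only, none or still open, it means among the compounds named here.

Compound 2, drawn as `CC1(C)C[C@H](Nc2cc(NCc3cnccc3C(F)(F)F)ncc2C#N)CC(C)(C)[C@@H]1O`, holds the lower of the two numbers recorded in an assay on isolated protein for inhibition of protein kinase C theta type (Homo sapiens), read by TR-FRET, with a stated time of 2 h; a lower number here means a stronger inhibitor, a higher number a weaker inhibitor: there compound 2 gives 12 nM. Its nearest neighbour in this assay is compound 1, `N#Cc1cnc(NCc2cnccc2C(F)(F)F)cc1NCCC1CCOCC1`, which in this assay gives 1200 nM, a gap that lies beyond the scatter of repeated measurements. The compound still to be measured is compound 3, `CC1(C)C[C@H](Nc2cc(NCc3cnccc3C(F)(F)F)ncc2C#N)CC(C)(C)[C@H]1O`. Its relation to compound 2 is the two compounds have the same atoms and bonds and differ only in configuration as drawn: 2 of 2 stereo elements differ (all stereocentres are inverted: mirror images); a stereocentre at a saturated ring carbon is drawn s in compound 2 and r in compound 3; a stereocentre at a saturated ring carbon is drawn s in compound 2 and r in compound 3; the two compounds have the same atoms and bonds and differ only in configuration as drawn, all stereocentres being inverted so that they are mirror images. Going by the values given here, no pair of measured compounds differing in configuration alone is available, so no measured step guides the expectation. He expects that inverting both stereocentres of compound 2 will weaken inhibition in this assay by a considerable margin, the expected step from compound 2 to compound 3 being a 10-fold higher number from compound 2 to compound 3 (1.00 log units; beyond the scatter). For compound 3 he therefore estimates 120 nM in this assay, within a range from 15 nM to 1000 nM.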

Compound 3, half-maximal inhibitory concentration: 20 nM
The estimate for compound 3 lay 6.0-fold (0.78 log units) above the measured number; measured number inside the range.
By their numbers in this assay, from the lowest: compounds 2 and 3 (each within the scatter of the next); then compound 1.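

In this assay the mirror-image pair shows a 1.7-fold higher number from compound 2 to compound 3 (0.22 log units; within the scatter), so inverting both stereocentres at the saturated ring carbons leaves the two numbers within the scatter of repeated measurements, and neither compound can be ranked above the other. Going by these compounds alone, until this pair, no two compounds had isolated configuration, so its contribution at this position could not be read from the measured compounds. Here, any comparison of the two numbers concerns configuration alone: the fact that compounds 2 and 3 differ only in the configuration as drawn

The compounds shown leave open whether a diastereomer with only one of the two stereocentres inverted would also fall within the scatter of compound 2 and compound 3. They also leave open how the number would respond if a methoxy group or an amine took the place of the hydroxyl group.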